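Series notes: from compound 1 to compound 4

A few compounds are considered here, and "the series" means these few. Any claim that something is new, unique, unknown or untested is made for them only; others in the source may bear on it.

Measured compounds:
- compound 1 `Nc1ncnn2c([C@@H]3O[C@H](CO)[C@@H](O)[C@H]3O)cc(C#Cc3ccc(F)cc3)c12`; in a functional assay on HL-60 cells (Homo sapiens) for antiproliferative activity, with a stated time of 72 h (on this read-out lower numbers stand for stronger inhibition and higher numbers for weaker inhibition), compound 1 gives > 100000 nM, a limit of the assay.
- compound 2 `COc1ccc(-c2cc([C@@H]3O[C@H](CO)[C@@H](O)[C@H]3O)n3ncnc(N)c23)cc1`; in this assay compound 2 gives > 100000 nM, also a limit of the assay.
- compound 3 `Nc1ncnn2c([C@@H]3O[C@H](CO)[C@@H](O)[C@H]3O)cc(-c3ccoc3)c12`; in this assay compound 3 gives 500 nM.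

Compound 1 stands only at a limit, not at a number; the same holds for compound 2, and both sit at the limit of > 100000 nM in this assay, at which 2 of the 3 values shown sit. Only compound 3, carrying furan-3-yl, gives a number, and the move is an at least 200-fold lower number from compound 1 to compound 3 (2.30 log units; beyond the scatter), with the matching an at least 200-fold lower number from compound 2 to compound 3 (2.30 log units; beyond the scatter). The step that the two limits leave unreadable from compound 1 to compound 2 cannot be read from the two limits.

Compound 4 `Nc1ncnn2c([C@@H]3O[C@H](CO)[C@@H](O)[C@H]3O)cc(/C=C/c3ccccc3)c12` is not yet measured. It differs from compound 1 by 2-phenylethenyl in place of 2-(4-fluorophenyl)ethynyl on an aromatic carbon. Among the compounds with values here, the bearing steps are the unreadable one from compound 1 to compound 2 and the large gain on going to the furan-3-yl of compound 3; no measured step covers a 2-phenylethenyl arm. Since both six-membered-ring arms seen so far, in compound 1 and compound 2, sit at the limit, compound 4 is expected to stay weak, possibly again at a limit, and the expected step is an at least 1.6-fold lower number from compound 1 to compound 4 (0.22 log units; that floor lies within the scatter). The estimate for compound 4 in this assay is 60000 nM, ranging from 8000 nM to 200000 nM.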

Compound 4, half-maximal inhibitory concentration: 2000 nM
For compound 4 the middle estimate is 30-fold (1.48 log units) above the measured one, outside the stated range (below it).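

The 2-phenylethenyl arm gives a readable value in this assay while keeping a six-membered aromatic ring of carbon only at this position, with an at least 50-fold lower number from compound 1 to compound 4 (1.69 log units; beyond the scatter) and an at least 50-fold lower number from compound 2 to compound 4 (1.69 log units; beyond the scatter). Such a ring therefore does not by itself hold a compound at the limit, and furan-3-yl is no longer the only arm that gives a number. Furan-3-yl still keeps an edge, with a 4.0-fold higher number from compound 3 to compound 4 (0.60 log units; beyond the scatter).

Going by these compounds, the arm of compound 4 differs from that of compound 1 in both the double bond and the missing fluorine, so the effect of each alone stays open, and the other two compounds remain limits, not numbers: the limit of > 100000 nM in this assay, at which 2 of the 4 values shown sit. An amine or a carboxylic acid on the phenyl ring of the 2-phenylethenyl arm, or a saturated ethyl chain in place of the double bond, also remains open.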